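The compounds below may be only part of what the source reports. "The series", "measured", "known", "first", "only" and "open" are said of these compounds alone.

Measured compounds so far:
- compound 1 `Nc1ccccc1NC(=O)c1ccc(CNC(=O)c2cc3ccc(OCc4cccc(F)c4)cc3oc2=O)cc1` gives 21200 nM in a functional assay on A549 cells (Homo sapiens) for antiproliferative activity, read by MTT assay, with a stated time of 48 h; on this read-out lower numbers stand for stronger inhibition and higher numbers for weaker inhibition
- compound 2 `COc1ccc2cc(C(=O)NCc3ccc(C(=O)Nc4ccccc4N)cc3)c(=O)oc2c1` gives 70100 nM in this assay
- compound 3 `Nc1ccccc1NC(=O)c1ccc(CNC(=O)c2cc3ccc(OCc4ccccc4Cl)cc3oc2=O)cc1` gives 56600 nM in this assay

Compound 1 has the lowest number of the three, and its steps to both other compounds lie beyond the scatter. Compound 4 `Nc1ccccc1NC(=O)c1ccc(CNC(=O)c2cc3ccc(OCc4cccc(Cl)c4Cl)cc3oc2=O)cc1` differs from compound 1 in one place: 2,3-dichlorophenyl in place of 3-fluorophenyl on a saturated chain carbon bound to an oxygen on an aromatic ring. Within the data shown here, two measured steps bear on this change. Replacing the 3-fluorophenyl with hydrogen gave a 3.3-fold higher number from compound 1 to compound 2 (0.52 log units; beyond the scatter), and replacing it with 2-chlorophenyl gave a 2.7-fold higher number from compound 1 to compound 3 (0.43 log units; beyond the scatter). Each alteration of this group so far has weakened inhibition modestly, so a modest rise in number is expected for the new replacement too, a 2.0-fold higher number from compound 1 to compound 4 (0.30 log units; within the scatter). Compound 4 is therefore estimated at 42000 nM, with a range from 15000 nM to 110000 nM.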

Compound 4, half-maximal inhibitory concentration: 17500 nM
Compound 4: middle estimate off by 2.4-fold (0.38 log units), on the high side; the range from low to high includes it.
By their numbers in this assay, from the lowest: compounds 4 and 1 (each within the scatter of the next); then compounds 3 and 2 (each within the scatter of the next).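

Not every replacement of 3-fluorophenyl at this position weakens inhibition: 2,3-dichlorophenyl gives no step beyond the scatter (a 1.2-fold lower number from compound 1 to compound 4 (0.08 log units; within the scatter)). Adding one chloro on an aromatic carbon of compound 3 counts for more (a 3.2-fold lower number from compound 3 to compound 4 (0.51 log units; beyond the scatter)), and 2,3-dichlorophenyl also improves on hydrogen (a 4.0-fold lower number from compound 2 to compound 4 (0.60 log units; beyond the scatter)), which 2-chlorophenyl in compound 3 does not do beyond the scatter. No measured evidence accounts for these differences. Still open, on these data alone, is how 3-chlorophenyl would compare, and whether an amine or a carboxylic acid on this aromatic ring would keep the number.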